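Replacing a Phenoxybutyl Ester with a Pyridine Ester

A few compounds are considered here, and "the series" means these few. Any claim that something is new, unique, unknown or untested is made for them only; others in the source may bear on it.

Compound 1 `O=C(CCCCOc1ccccc1)OCC1COCCOCCOCCOCCOCCO1` is an ester built on a large polyether ring. In a functional assay on HBL-100 cells (Homo sapiens) for inhibition, read by sulforhodamine B assay, with a stated time of 48 h (on this read-out higher numbers stand for weaker inhibition of growth and lower numbers for stronger inhibition of growth), compound 1 reaches only the upper limit of the measurement, > 100000 nM, so its potency is not known as a number. Compound 2 `O=C(/C=C/c1ccccc1)OCC1COCCOCCOCCOCCOCCO1` carries a 2-phenylethenyl group on the carbonyl carbon and gives 57000 nM in this assay. The step of an at least 1.7-fold lower number from compound 1 to compound 2 (0.24 log units; that floor lies within the scatter) is small. Compound 3 `O=C(CCCCC1CCCCC1)OCC1COCCOCCOCCOCCO1` also stands at the limit, > 100000 nM, in this assay. The known values thus cluster at the limit of > 100000 nM in this assay, at which 2 of the 3 values shown sit.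

Compound 4 `O=C(OCC1COCCOCCOCCOCCOCCO1)c1cccnc1` differs from compound 1 in one place: pyridin-3-yl in place of 4-phenoxybutyl on a carbonyl carbon. Among the compounds with values here, the only measured step at this position is the one from compound 1 to compound 2, and it stayed within the scatter. Exchanging the group on the carbonyl carbon for pyridin-3-yl, an aromatic ring with one hetero atom, is therefore expected to leave the number close to where compound 1 stands, most likely at the limit once more. Compound 4 is expected to give 100000 nM in this assay, between 40000 nM and 300000 nM, which means an expected step of a number no higher from compound 1 to compound 4 (the limit leaves the size open).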

Compound 4, concentration for 50% growth inhibition: > 100000 nM
Compound 4 ended at the assay's limit; the forecaster's own chance of this, stated with the estimate: 70%; the middle value lies on the limit itself.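

The new result adds a group of a different kind at this position: with pyridin-3-yl, an aromatic ring with one hetero atom, on the carbonyl carbon, the shared core still gives no readable growth inhibition in this assay. Against the one compound with a number, the result is an at least 1.7-fold higher number from compound 2 to compound 4 (0.24 log units; that floor lies within the scatter), so it does not show that 2-phenylethenyl does better than pyridin-3-yl here. The step between compound 1 and compound 4 cannot be read, as both values are limits of the assay, and the series now gathers at a single point: the limit of > 100000 nM in this assay, at which 3 of the 4 values shown sit.

On these data alone, whether any group on this carbonyl carbon can move the number clearly beyond the scatter stays open. An aminobutyl chain or a carboxylic acid at this place would test that, and so would an amide in place of the ester.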